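Thiophene attachment point in three hydroxyphenyl pyridines

A few compounds are considered here, and "the series" means these few. Any claim that something is new, unique, unknown or untested is made for them only; others in the source may bear on it.

Three compounds that share one core were tested in a functional assay on HCT-15 cells (Homo sapiens) for cytotoxicity, read by ELISA, with a stated time of 2 days; on this read-out higher numbers stand for weaker inhibition and lower numbers for stronger inhibition. Compound 1 `Oc1cccc(-c2cc(-c3ccccc3)cc(-c3cccs3)n2)c1` gives 10900 nM there. Compound 2 `Oc1cccc(-c2cc(-c3ccccc3)cc(-c3ccsc3)n2)c1` differs from compound 1 by thiophen-3-yl in place of thiophen-2-yl on an aromatic carbon; in this assay compound 2 gives 7660 nM, and the step is a 1.4-fold lower number from compound 1 to compound 2 (0.15 log units; within the scatter). Compound 3 `Oc1ccc(-c2cc(-c3ccccc3)cc(-c3cccs3)n2)cc1` differs from compound 1 by 4-hydroxyphenyl in place of 3-hydroxyphenyl on an aromatic carbon; in this assay compound 3 gives 12500 nM, and that step is a 1.1-fold higher number from compound 1 to compound 3 (0.06 log units; within the scatter). Compound 4 `Oc1ccc(-c2cc(-c3ccccc3)cc(-c3ccsc3)n2)cc1` has not yet been measured. It differs from compound 3 by thiophen-3-yl in place of thiophen-2-yl on an aromatic carbon. This is the same kind of change as from compound 1 to compound 2, but the surroundings are not identical: in the measured pair the place is meta to a 3-hydroxyphenyl group, whereas in compound 3 and compound 4 it is meta to a 4-hydroxyphenyl group. Because the measured step was a 1.4-fold lower number from compound 1 to compound 2 (0.15 log units; within the scatter), only a small step, a 1.4-fold lower number from compound 3 to compound 4 (0.14 log units; within the scatter), is expected for compound 4 in this assay. On that basis compound 4 is estimated at 9000 nM, expected to lie between 4000 nM and 20000 nM.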

Compound 4, half-maximal inhibitory concentration: 1100 nM
The estimate for compound 4 lay 8.2-fold (0.91 log units) above the measured number; the whole stated range lies above it.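

In this assay the change to thiophen-3-yl gave an 11-fold lower number from compound 3 to compound 4 (1.06 log units; beyond the scatter), and this did not match the same change on the other core: the same change on two cores in this assay, a 1.4-fold lower number (0.15 log units; within the scatter) from compound 1 to compound 2 and an 11-fold lower number (1.06 log units; beyond the scatter) from compound 3 to compound 4, 8.0-fold (0.90 log units) apart, beyond the scatter of two such steps. The change to 4-hydroxyphenyl gave a 7.0-fold lower number from compound 2 to compound 4 (0.84 log units; beyond the scatter), and it too failed to carry over: the same change on two cores in this assay, a 1.1-fold higher number (0.06 log units; within the scatter) from compound 1 to compound 3 and a 7.0-fold lower number (0.84 log units; beyond the scatter) from compound 2 to compound 4, 8.0-fold (0.90 log units) apart, beyond the scatter of two such steps. The two changes therefore did not act independently in these four compounds, with the much lower number appearing only in compound 4, where thiophen-3-yl and 4-hydroxyphenyl occur together, but this single set of four compounds in one cell assay does not show why this happens or whether it holds elsewhere in the series.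

The compounds shown leave open whether the lower number survives if the hydroxyl of the 4-hydroxyphenyl group is replaced by a methoxy group or an amine. They also leave open whether compound 4 stands apart in the same way on other cell lines.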